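This account rests on a few compounds, and the source may have more. Where it says the series, first, only, none or still open, it means among the compounds named here.

Measured so far:
compound 1 `COC1=CC(=O)c2c(c(COc3ccccc3)c(C)n2C)C1=O` — 962 nM
compound 2 `COC1=CC(=O)c2c(c(COc3ccccc3[N+](=O)[O-])c(C)n2C)C1=O` — 104 nM
compound 3 `COC1=CC(=O)c2c(COc3ccccc3)c(C)n(C)c2C1=O` — 409 nM

All three were tested in a functional assay on MIA PaCa-2 cells (Homo sapiens) for cytotoxicity, read by MTT assay, with a stated time of 72 h; on this read-out higher numbers stand for weaker inhibition and lower numbers for stronger inhibition. Compound 2 differs from compound 1 only by nitro in place of hydrogen on an aromatic carbon, and that single change gave a 9.3-fold lower number from compound 1 to compound 2 (0.97 log units; beyond the scatter). Compound 3 has the same atoms as compound 1 joined differently; the difference between the two cores is not broken down here, and in this assay compound 3 gives 409 nM against compound 1 with 962 nM.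

Compound 4 `COC1=CC(=O)c2c(COc3ccccc3[N+](=O)[O-])c(C)n(C)c2C1=O` has not yet been measured. It differs from compound 3 by nitro in place of hydrogen on an aromatic carbon, the same kind of change already seen, at a place described in the same words. Within the data shown here, the expectation for compound 4 therefore rests on a 9.3-fold lower number from compound 1 to compound 2 (0.97 log units; beyond the scatter), the only example of this change. Compound 4 is expected to give about 55 nM in this assay, likely between 20 nM and 160 nM. That would mean an expected step of a 7.4-fold lower number from compound 3 to compound 4 (0.87 log units; beyond the scatter), slightly smaller than the earlier one, since it rests on one example alone.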

Compound 4, half-maximal inhibitory concentration: 178 nM
The estimate for compound 4 lay 3.2-fold (0.51 log units) below the measured number; measured number above the stated range.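

In this assay, nitro in place of hydrogen on an aromatic carbon again lowered the number, giving a 2.3-fold lower number from compound 3 to compound 4 (0.36 log units; beyond the scatter) on the second core. The direction of the change carried over between the two cores, but its size did not: the same change on two cores in this assay, a 9.3-fold lower number (0.97 log units; beyond the scatter) from compound 1 to compound 2 and a 2.3-fold lower number (0.36 log units; beyond the scatter) from compound 3 to compound 4, 4.0-fold (0.60 log units) apart, beyond the scatter of two such steps. So a step seen on one core in this series gives the direction on the other but not a reliable size, and these two pairs do not show what in the cores sets the gap or how the change would behave on a further core.

The compounds shown leave open whether an amine or a carboxylic acid in the place of nitro would also lower the number. They also leave open whether either group would show the same gap between the two cores.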